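The source may hold more compounds than are shown below. What is called first, only, known or untested is meant among the compounds shown, and "the series" means these compounds.

Measured compounds:
- compound 1 `Cc1cnc(C(=O)Nc2ccc3ncccc3c2)cn1`
- compound 2 `Cc1cnc(C(=O)Nc2cc(F)cc3cccnc23)cn1`

In a functional assay on MIA PaCa-2 cells (Homo sapiens) for inhibition, read by MTT assay, with a stated time of 72 h (a lower number here means a stronger inhibitor, a higher number a weaker inhibitor), compound 1 sits at a limit of the assay, > 10000 nM, and gives no number. Among the measured compounds shown here, compound 2 gives 310 nM in this assay, the only number so far. The other value shown, that of compound 1, is a limit, as the limit of > 10000 nM in this assay, at which 1 of the 2 values shown sits, records.

Compound 3 `COc1cc(NC(=O)c2cnc(C)cn2)c2ncccc2c1` differs from compound 2 by methoxy in place of fluoro on an aromatic carbon. For the measured compounds named here, no measured step of this kind is at hand, so the size of the change in this assay is open; a shift within or slightly beyond the scatter seems most likely, in either direction. For compound 3 the expected step is a 1.9-fold higher number from compound 2 to compound 3 (0.29 log units; within the scatter), giving an estimated 600 nM, with a range from 150 nM to 3000 nM.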

Compound 3, half-maximal inhibitory concentration: 270 nM
Beside the measured number, compound 3's estimate is 2.2-fold (0.35 log units) above it, and the stated range covers the measured number.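

On this aromatic carbon, methoxy in place of fluoro gives a 1.1-fold lower number from compound 2 to compound 3 (0.06 log units; within the scatter) in this assay, the first step read in this series. Compound 2 and compound 3 are therefore not told apart here, although methoxy enters with 2 heavy atoms and 1 hydrogen-bond acceptor, and fluoro leaves with 1 heavy atom and 0 hydrogen-bond acceptors. Nothing at hand bears on a cause for this step.

Going by these compounds, whether an amine, a carboxylic acid or a longer chain on this carbon would keep the number in this range stays open. These two compounds also say nothing about other positions of the shared core.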